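The compounds below may be only part of what the source reports. "The series", "measured", "known", "first", "only" and "open" are said of these compounds alone.

Working notes on the series.

Compound 3 `COC(=O)c1cc(-c2cccc(NC(=O)c3ccc(/C=C/C(=O)c4cccc(OC)c4)cc3)c2)on1` is the starting point of this step. In an ADME assay on Vero cells (Chlorocebus sabaeus) for cytotoxicity, read by MTT assay, with a stated time of 72 h (on this read-out higher numbers stand for lower toxicity in this test and lower numbers for higher toxicity in this test), compound 3 gives > 100 ug/mL, which is a limit of the assay and not a number. Compound 1 `COC(=O)c1cc(-c2cccc(NC(=O)c3ccc(/C=C/C(=O)c4cccc(Cl)c4)cc3)c2)on1` in this assay gives > 2.5 ug/mL, again only a limit. Compound 2 `COC(=O)c1cc(-c2cccc(NC(=O)c3ccc(/C=C/C(=O)c4ccc(C)c(F)c4)cc3)c2)on1` in this assay gives > 50 ug/mL, also a limit. Among the compounds with values here, every result so far is therefore a limit: one value sits at the limit of > 100 ug/mL in this assay, at which 1 of the 3 values shown sits, one at the limit of > 2.5 ug/mL in this assay, at which 1 of the 3 values shown sits, and one at the limit of > 50 ug/mL in this assay, at which 1 of the 3 values shown sits, and no compound has a measured number.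

Compound 4 `COC(=O)c1cc(-c2cccc(NC(=O)c3ccc(C4OC4C(=O)c4ccc(Cl)cc4)cc3)c2)on1` differs from compound 3 by 3-((4-chlorophenyl)carbonyl)oxiran-2-yl in place of 2-((3-methoxyphenyl)carbonyl)ethenyl on an aromatic carbon. The steps measured so far all alter the aryl ring on the carbonyl carbon, so they are the closest comparison: a step that the two limits leave unreadable from compound 1 to compound 3, a step that the two limits leave unreadable from compound 2 to compound 3 and a step that the two limits leave unreadable from compound 1 to compound 2. None of them yields a readable size, so they give no direction for the present change, and nothing measured speaks to the three-membered ring that enters.

For compound 4 the estimate is therefore a placeholder near the lower limits seen rather than a defined step; the value is expected to be 50 ug/mL, within 10 ug/mL to 200 ug/mL. The step expected in this assay is an at least 2.0-fold lower number from compound 3 to compound 4 (0.30 log units; that floor lies within the scatter).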

Compound 4, half-maximal cytotoxic concentration: > 20 ug/mL
Compound 4 ended at the assay's limit; the forecaster's own chance of this, stated with the estimate: 50%; the middle value does not contradict the limit.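

In this assay compound 4 gives > 20 ug/mL, which is a limit of the assay and not a number. The steps to compound 4 from compound 1, compound 2 and compound 3 cannot be read, as all four results are limits. The compounds shown leave open whether 3-((4-chlorophenyl)carbonyl)oxiran-2-yl in place of 2-((3-methoxyphenyl)carbonyl)ethenyl shifts the half-maximal cytotoxic concentration in either direction.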